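Working notes: replacing morpholin-4-yl with 6-aminohexyl

This account rests on a few compounds, and the source may have more. Where it says the series, first, only, none or still open, it means among the compounds named here.

Measured in a functional assay on HT-29 cells (Homo sapiens) for antiproliferative activity, read by MTT assay, with a stated time of 96 h; on this read-out higher numbers stand for weaker inhibition and lower numbers for stronger inhibition:
- Compound 1 `O=C1CC2(CCCCC2)Oc2c1ccc1ccccc21`: 6150 nM
- Compound 2 `CSC(=S)N/N=C1\CC2(CCCCC2)Oc2c1ccc1ccccc21`: 4130 nM
- Compound 3 `S=C(N/N=C1\CC2(CCCCC2)Oc2c1ccc1ccccc21)N1CCOCC1`: 9310 nM

Compound 3 lies within the scatter of compound 1, and its number is higher than that of compound 2. Compound 4 `NCCCCCCC(=S)N/N=C1\CC2(CCCCC2)Oc2c1ccc1ccccc21` has 6-aminohexyl in place of morpholin-4-yl on a thiocarbonyl carbon. Going by the values given here, one measured step bears on this place: a 2.3-fold higher number from compound 2 to compound 3 (0.35 log units; beyond the scatter). Among the compounds with values here, no measured compound carries an aminoalkyl chain there, so the direction is weakly supported. In this assay, a modest step toward a lower number is expected, similar in size to that one. The estimated step is a 2.1-fold lower number from compound 3 to compound 4 (0.32 log units; beyond the scatter). For compound 4 the estimate is 4500 nM, with an expected range of 1500 nM to 13000 nM.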

Compound 4, half-maximal inhibitory concentration: 3870 nM
Compound 4: the middle estimate sits 1.2-fold (0.07 log units) above what was measured; measured number inside the range.
By their numbers in this assay, from the lowest: compounds 4, 2, 1 and 3 (each within the scatter of the next, the first and the last beyond it).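

In this assay the place on the thiocarbonyl carbon now gives a second step beyond the scatter (a 2.4-fold lower number from compound 3 to compound 4 (0.38 log units; beyond the scatter)), opposite in direction to the earlier one (a 2.3-fold higher number from compound 2 to compound 3 (0.35 log units; beyond the scatter)). Methylsulfanyl and 6-aminohexyl cannot be told apart (a 1.1-fold lower number from compound 2 to compound 4 (0.03 log units; within the scatter)), so among these three groups only morpholin-4-yl stands apart. No measured evidence bears on the reason for this.

Going by these compounds, whether the terminal amine or the chain of 6-aminohexyl matters stays open. A plain hexyl chain, a shorter aminoalkyl chain or a piperidin-1-yl ring at this place would help separate the two.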